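The source may hold more compounds than are shown below. What is called first, only, known or untested is meant among the compounds shown, and "the series" means these compounds.

The compounds measured so far in an ADME assay on SW480 cells (Homo sapiens) for cytotoxicity, read by MTT assay, with a stated time of 72 h; a higher number here means a weaker inhibitor, a lower number a stronger inhibitor:

compound 1, `CCCCCN1C(=O)C/C(=C\c2cccc(C(=O)NCCCC)c2)C1=O`, gives > 100000 nM, which is a limit of the assay and not a number.
compound 2, `COc1ccc(NC(=O)c2cccc(/C=C3\CC(=O)N(c4ccccc4)C3=O)c2)c(C)c1`, gives > 100000 nM, again a limit of the assay.
compound 3, `COc1ccc(NC(=O)c2cccc(CC3CC(=O)N(c4ccc(C)cc4)C3=O)c2)cc1`, gives > 100000 nM, again a limit of the assay.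

Compound 2 therefore stands where every measured compound stands: at the limit, with no number of its own. This is summed up by the limit of > 100000 nM in this assay, at which 3 of the 3 values shown sit. For the measured compounds named here, no step between two measured compounds is available, so nothing shows how any structural change moves this read-out.

The unmeasured compound is compound 4, `O=C(Nc1cccc(F)c1)c1cccc(/C=C2\CC(=O)N(c3ccccc3)C2=O)c1`. Its difference from compound 2 is 3-fluorophenyl in place of 4-methoxy-2-methylphenyl on an amide-type nitrogen, on an amide-type nitrogen whose other neighbour is a carbonyl carbon.

With all three measured compounds at the limit, the step expected from compound 2 to compound 4 is none beyond the scatter: a number no higher from compound 2 to compound 4 (the limit leaves the size open). Compound 4 is thus expected to give 100000 nM, within a range from 50000 nM to 200000 nM, most likely reported as a limit rather than a number.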

Compound 4, half-maximal inhibitory concentration: > 100000 nM
Compound 4 was reported as a limit (the forecaster's own chance of this, stated with the estimate: 85%); the middle value lies on the limit itself.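

Compound 2 and compound 4 are both reported as limits in this assay, so no step can be read for 3-fluorophenyl in place of 4-methoxy-2-methylphenyl: the limit of > 100000 nM in this assay, at which 4 of the 4 values shown sit. The compounds shown leave open which structural change, if any, would give a measurable number in this assay and not a limit.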